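This account rests on a few compounds, and the source may have more. Where it says the series, first, only, none or still open, it means among the compounds named here.

Of the compounds shown here, three of one shared core have been tested in a functional assay on the whole organism for inhibition, with Rattus norvegicus as the target (on this read-out lower numbers stand for an effect already at smaller amounts and higher numbers for an effect only at larger amounts of compound), and every one of them reached only the upper limit of that test. Compound 1 `CC1CC/C(=N\Nc2ccccc2)c2ncc(C(=O)NN)c(=O)n21` carries an aminocarbamoyl group on an aromatic carbon; in this assay compound 1 gives > 1000 umol/kg, which is a limit of the assay and not a number. Compound 2 `CC1CC/C(=N\Nc2ccccc2)c2ncc(C#N)c(=O)n21` has a cyano group in its place; in this assay compound 2 gives > 1000 umol/kg, again only a limit. The step that the two limits leave unreadable from compound 1 to compound 2 therefore cannot be sized. Compound 3 `CC1CC/C(=N\Nc2ccccc2F)c2ncc(C(=O)O)c(=O)n21` bears a carboxylic acid on the core and a 2-fluorophenyl group on the amine nitrogen; in this assay compound 3 gives > 1000 umol/kg, once more a limit. Compound 3 thus stands where all the others stand, because of the limit of > 1000 umol/kg in this assay, at which 3 of the 3 values shown sit.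

Compound 4 `CC1CC/C(=N\Nc2ccc(I)cc2)c2ncc(C(=O)O)c(=O)n21` differs from compound 3 in one place: 4-iodophenyl in place of 2-fluorophenyl on an amine nitrogen. For the measured compounds named here, no measured step touches this change, so nothing here points in either direction. Compound 4 is expected to give about 2000 umol/kg, within 700 umol/kg to 6000 umol/kg, a step that the limit leaves unreadable from compound 3 to compound 4 that would most likely again be reported only as a limit.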

Compound 4, dose for 50% inhibition: > 1000 umol/kg
Compound 4: no number, only a limit; the forecaster's own chance of this, stated with the estimate: 80%; the middle value is on the limit's open side.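

In this assay compound 3 and compound 4 both end at a limit rather than a number, so no size can be read for the step between them. The compounds shown leave open whether any change on the shared core would give a readable value: the limit of > 1000 umol/kg in this assay, at which 4 of the 4 values shown sit.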